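Piperidinylmethylcarbonyl in Place of the Cyanophenylsulfonyl Cap

A few compounds are considered here, and "the series" means these few. Any claim that something is new, unique, unknown or untested is made for them only; others in the source may bear on it.

Measured compounds:
Compound 1, `CN(C)c1ccc(C(=O)N2CCC(NS(=O)(=O)c3cc(S(=O)(=O)c4ccccc4)ccc3C(F)(F)F)CC2)cn1`, gives 70 nM in an assay on U2OS cells for inhibition of secreted frizzled-related protein 1 (Homo sapiens), read by a luciferase reporter, with a stated time of 18 h; on this read-out higher numbers stand for an effect only at larger amounts of compound and lower numbers for an effect already at smaller amounts.
Compound 2, `N#Cc1cccc(S(=O)(=O)N2CCC(NS(=O)(=O)c3cc(S(=O)(=O)c4ccccc4)ccc3C(F)(F)F)CC2)c1`, gives 170 nM in this assay.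

Within the data shown here, of the two measured compounds, compound 2 shows the higher number in this assay; the only step measured, a 2.4-fold higher number from compound 1 to compound 2 (0.39 log units; beyond the scatter), separates it from compound 1 and lies beyond the scatter. Compound 3, `O=C(CC1CCNCC1)N1CCC(NS(=O)(=O)c2cc(S(=O)(=O)c3ccccc3)ccc2C(F)(F)F)CC1`, has not yet been measured. It differs from compound 2 in one place: ((piperidin-4-yl)methyl)carbonyl in place of (3-cyanophenyl)sulfonyl on an amine nitrogen in a ring. Among the measured compounds shown here, the one measured step bears on this change only loosely: it exchanged a carbonyl-linked aromatic group for a sulfonyl-linked one on the same amine nitrogen in a ring, and the number rose modestly. For the measured compounds named here, compound 3 returns to a carbonyl linkage, though with a non-aromatic ring, so a move back toward compound 1 is possible, but a non-aromatic cap has no precedent here, and a shift in either direction cannot be excluded. Compound 3 is therefore expected to give a number close to that of compound 2, with a 1.2-fold higher number from compound 2 to compound 3 (0.07 log units; within the scatter) as the estimated step and a wide range. The estimate for compound 3 is 200 nM, expected to fall between 50 nM and 1000 nM.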

Compound 3, half-maximal effective concentration: 210 nM
Beside the measured number, compound 3's estimate is 1.1-fold (0.02 log units) below it, within the range that was stated.
By their numbers in this assay, from the lowest: compound 1; then compounds 2 and 3 (each within the scatter of the next).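

At this amine nitrogen in a ring, this assay does not separate the two caps: a 1.2-fold higher number from compound 2 to compound 3 (0.09 log units; within the scatter), so ((piperidin-4-yl)methyl)carbonyl matches (3-cyanophenyl)sulfonyl within the scatter, although it has no aromatic ring and brings a hydrogen-bond donor. With the carbonyl kept, placing (piperidin-4-yl)methyl instead of 6-(dimethylamino)pyridin-3-yl on the carbonyl carbon gives a 3.0-fold higher number from compound 1 to compound 3 (0.48 log units; beyond the scatter), a modest step beyond the scatter, which shows that a carbonyl link alone does not carry the lower number of compound 1, and that the group on that carbonyl counts as well. No measurement is available to explain either result.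

The compounds shown leave open which part of 6-(dimethylamino)pyridin-3-yl goes with the lower number, a question that a plain phenyl or a pyridin-3-yl without the dimethylamino group on the same carbonyl would address. They also leave open what the ring nitrogen and the methylene of the (piperidin-4-yl)methyl group contribute, which a cyclohexylmethyl group, an N-methylpiperidine or a directly attached piperidin-4-yl would test.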